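Nitro to hydroxyl on the ring nitrogen: cytotoxicity outlook

The source may hold more compounds than are shown below. What is called first, only, known or untested is meant among the compounds shown, and "the series" means these compounds.

Compound 1 `Cc1cc(/C=C2\SC(=S)N(c3ccccc3)C2=O)c(C)n1-c1cccc(-c2nnn[nH]2)c1`: 61000 nM
Compound 2 `Cc1cc(/C=C2\SC(=S)N(c3cccc([N+](=O)[O-])c3)C2=O)c(C)n1-c1cccc(-c2nnn[nH]2)c1`: 77000 nM

In an ADME assay on MT2 cells (Homo sapiens) for cytotoxicity, read by XTT assay, with a stated time of 4 days (a higher number here means that more compound is tolerated, a lower number that less compound is tolerated), compound 2 gives 77000 nM, the highest of the two numbers; the nearest, compound 1 at 61000 nM, sits within the scatter. Compound 3 `Cc1cc(/C=C2\SC(=S)N(c3ccc(O)cc3)C2=O)c(C)n1-c1cccc(-c2nnn[nH]2)c1` differs from compound 2 as follows: 4-hydroxyphenyl in place of 3-nitrophenyl on an amide-type nitrogen in a ring. Within the data shown here, the single measured step, a 1.3-fold higher number from compound 1 to compound 2 (0.10 log units; within the scatter), concerns only a nitro added to hydrogen and stayed within the scatter, so no step of size is expected here either. Compound 3 is therefore estimated at 65000 nM (range 30000 nM to 140000 nM), a step of a 1.2-fold lower number from compound 2 to compound 3 (0.07 log units; within the scatter) that is expected to stay within the scatter.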

Compound 3, half-maximal cytotoxic concentration: 45600 nM
For compound 3 the middle estimate is 1.4-fold (0.15 log units) above the measured one, and the stated range covers the measured number.
By their numbers in this assay, from the lowest: compounds 3, 1 and 2 (each within the scatter of the next).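

In this assay, replacing 3-nitrophenyl with 4-hydroxyphenyl on the amide-type nitrogen in a ring gives a 1.7-fold lower number from compound 2 to compound 3 (0.23 log units; within the scatter), and adding a hydroxy to the unsubstituted phenyl ring gives a 1.3-fold lower number from compound 1 to compound 3 (0.13 log units; within the scatter). The earlier compounds shown here showed only a nitro on this phenyl ring, and a hydroxy now also leaves the number within the scatter of both. No measured finding offers an explanation for these numbers. The compounds shown leave open whether an amine or a carboxylic acid on this phenyl ring would also stay within the scatter.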